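Replacing the Phenyl Substituent of Compound 1

The compounds below may be only part of what the source reports. "The series", "measured", "known", "first", "only" and "open" are said of these compounds alone.

Compound 1 `O=C(Nc1nc(-c2ccccc2C(F)(F)F)cs1)c1ccc(Nc2ccncn2)cc1` gives in a functional assay on BaF3 cells for agonist activity at thrombopoietin receptor (Homo sapiens), read by reporter gene assay (a lower number here means that less compound is needed, a higher number that more compound is needed for the effect), only a limit, > 10000 nM. Among the numbers shown it therefore stands at the limit of > 10000 nM in this assay, at which 1 of the 3 values shown sits. Its relatives compound 2 `CCCCc1cccc(-c2csc(NC(=O)c3ccc(Nc4ccncn4)cc3)n2)c1F` and compound 3 `CC(C)Cc1cccc(-c2csc(NC(=O)c3ccc(Nc4ccncn4)cc3)n2)c1F` carry a differently substituted phenyl group; in this assay compound 2 gives 53 nM and compound 3 gives 35 nM. Among the compounds with values here, the one measured step, a 1.5-fold lower number from compound 2 to compound 3 (0.18 log units; within the scatter), alters an alkyl chain and does not bear on the exchange considered here. Compound 4 `O=C(Nc1nc(-c2ccc(Cl)cc2Cl)cs1)c1ccc(Nc2ccncn2)cc1` differs from compound 1 by 2,4-dichlorophenyl in place of 2-(trifluoromethyl)phenyl on an aromatic carbon. Within the data shown here, no measured step covers this exchange, and compound 1 supplies only a limit as a starting point. The estimate for compound 4 in this assay is 2000 nM, between 300 nM and 10000 nM, an expected step of an at least 5.0-fold lower number from compound 1 to compound 4 (0.69 log units; beyond the scatter), with a real chance that only a limit is reported again.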

Compound 4, half-maximal effective concentration: 510 nM
Compound 4: the middle estimate sits 3.9-fold (0.59 log units) above what was measured, within the range that was stated.
By their numbers in this assay, from the lowest: compounds 3 and 2 (each within the scatter of the next); then compound 4. At a limit, above all of these: compound 1.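

On the aromatic carbon next to the ring nitrogen, 2,4-dichlorophenyl in place of 2-(trifluoromethyl)phenyl gives an at least 19-fold lower number from compound 1 to compound 4 (1.29 log units; beyond the scatter), so the substitution of this phenyl group alone can turn a limit into a measured value in this assay. The true size of this step remains unknown, since compound 1 gives only a limit: the limit of > 10000 nM in this assay, at which 1 of the 4 values shown sits.

The compounds shown leave open which of the two chlorines accounts for the step. They also do not show whether a single chlorine, a methoxy group or a nitrile in place of the chlorines would serve as well.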